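Hydroxy to methoxy: carrying one step to a second pair

This account rests on a few compounds, and the source may have more. Where it says the series, first, only, none or still open, it means among the compounds named here.

Compound 1 `O=C(Nc1cccc(-n2cc(-c3ccncc3)c(-c3cc(O)cc(Cl)c3)n2)c1)Nc1ccc(Cl)c(Cl)c1` is measured in a functional assay on RXF 393 cells (Homo sapiens) for inhibition, read by sulforhodamine B assay, with a stated time of 48 h, tested at 10 uM (on this read-out higher numbers stand for a weaker effect at the one concentration tested and lower numbers for a stronger effect), at -70.3%. Compound 2 `COc1cc(Cl)cc(-c2nn(-c3cccc(NC(=O)Nc4ccc(Cl)c(Cl)c4)c3)cc2-c2ccncc2)c1` differs from it by methyl in place of hydrogen on an oxygen on an aromatic ring and in this assay compound 2 gives 4.46%; the step is a number 74.8 percentage points higher from compound 1 to compound 2 (beyond the scatter). Compound 3 `O=C(Nc1cccc(-n2cc(-c3ccncc3)c(-c3cc(O)cc(Cl)c3)n2)c1)c1cc(C(F)(F)F)cc(C(F)(F)F)c1` has a different core; how the core of compound 3 differs from the core of compound 1 is not broken down here. In this assay compound 3 gives -10.4%, the second highest of the three numbers, nearest to compound 2 and furthest from compound 1. Compound 4 `COc1cc(Cl)cc(-c2nn(-c3cccc(NC(=O)c4cc(C(F)(F)F)cc(C(F)(F)F)c4)c3)cc2-c2ccncc2)c1` differs from compound 3 by methyl in place of hydrogen on an oxygen on an aromatic ring, the same change at the same place as between compound 1 and compound 2. The step of a number 40.4 percentage points higher from compound 3 to compound 4 (beyond the scatter) is expected to be smaller than the earlier one because compound 3 already sits at -10.4% and has less room upward. Compound 4 is therefore estimated at 30%, between -5% and 70%.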

Compound 4, a percentage reported as activity, at one concentration (the size of the read-out at that concentration, not a potency): 67.7%
Compound 4: the middle estimate sits 37.7 percentage points below what was measured; the measured number falls inside the stated range.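

On both cores, the change from hydroxy to methoxy on the 3-chloro-5-hydroxyphenyl group moves the read-out the same way in this assay, and the new step is a number 78.1 percentage points higher from compound 3 to compound 4 (beyond the scatter). Set beside the earlier step, the change carries from one core to the other with its size kept: the same change on two cores in this assay, a number 74.8 percentage points higher (beyond the scatter) from compound 1 to compound 2 and a number 78.1 percentage points higher (beyond the scatter) from compound 3 to compound 4, 3.3 percentage points apart, within the scatter of two such steps

Two pairs show this for a single change at a single concentration; they do not show why the methoxy compounds read higher, or that a further core would follow. The compounds shown leave open whether an ethoxy group, a longer chain on that oxygen or an amine in place of the hydroxy would give a step of similar size.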